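The source may report more compounds than this note shows. Statements on the series, on what has been measured and on what is new or still open speak of the compounds shown alone.

The measured compounds are:

Compound 1, `CCC(=O)NCCCCc1ccc(OC)cc1`, which in an assay for binding affinity to melatonin receptor (Gallus gallus) (on this read-out lower numbers stand for stronger inhibition and higher numbers for weaker inhibition), gives 1400 nM.
Compound 2, `CCCC(=O)NCCCCc1ccc(OC)cc1`, which in this assay gives 822 nM.
Compound 3, `CCC(=O)NCCCc1cccc(Br)c1`, which in this assay gives 318 nM.

Compounds 1 and 2 share one core and differ in a single place: methyl in place of hydrogen on a saturated chain carbon, two bonds along the chain from a carbonyl carbon. This change brought a 1.7-fold lower number from compound 1 to compound 2 (0.23 log units; within the scatter), a step that stays inside the usual scatter, so these two values cannot be told apart with confidence. Compound 3 has a different core; how the core of compound 3 differs from the core of compound 1 is not broken down here. Its number is lower than that of compound 2 and lower still than that of compound 1, and both of those gaps lie beyond the scatter.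

Compound 4, `CCCC(=O)NCCCc1cccc(Br)c1`, has not yet been measured. It differs from compound 3 exactly as compound 2 differs from compound 1: methyl in place of hydrogen on a saturated chain carbon, two bonds along the chain from a carbonyl carbon, at the same place along the chain. Among the compounds with values here, the only measured example of this change is the step from compound 1 to compound 2, which was small.

For compound 4 in this assay the expected step is a 1.5-fold lower number from compound 3 to compound 4 (0.18 log units; within the scatter), because a 1.7-fold lower number from compound 1 to compound 2 (0.23 log units; within the scatter) was within the scatter and nothing here suggests the change behaves differently on the core of compound 3. The estimate for compound 4 is therefore 210 nM, expected to fall between 90 nM and 500 nM.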

Compound 4, inhibition constant: 354 nM
Beside the measured number, compound 4's estimate is 1.7-fold (0.23 log units) below it; measured number inside the range.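

In this assay, placing a methyl in place of hydrogen on the saturated chain carbon, two bonds along the chain from the carbonyl carbon, gave a 1.1-fold higher number from compound 3 to compound 4 (0.05 log units; within the scatter), so the values of these two compounds cannot be told apart. Set beside the earlier example, the change reads the same on both cores as far as this assay can resolve: the same change on two cores in this assay, a 1.7-fold lower number (0.23 log units; within the scatter) from compound 1 to compound 2 and a 1.1-fold higher number (0.05 log units; within the scatter) from compound 3 to compound 4, 1.9-fold (0.28 log units) apart, within the scatter of two such steps This shows that, on these two cores, going from propanoyl to propylcarbonyl brought no step that stands clear of the usual scatter, and that a small step on one core was a fair guide to the step on the other; it does not show that the change has no effect at all, since a small real difference could hide inside the scatter, and two pairs cannot establish a rule for other cores in the series.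

The compounds shown leave open whether a longer chain, a branched chain, or an amine or carboxylic acid at the end of the chain would also leave the number in the same range. They also leave open which part of the core matters, as the core of compound 1 and the core of compound 3 are not linked by a single change.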